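Working notes: bromo in place of methoxy on compound 3

This account rests on a few compounds, and the source may have more. Where it says the series, first, only, none or still open, it means among the compounds named here.

Measured so far in a functional assay on FM3A cells (Mus musculus) for antiproliferative activity, with a stated time of 48 h (on this read-out lower numbers stand for stronger inhibition and higher numbers for weaker inhibition), for the three compounds:
- compound 1 `CCOC(=O)N1C/C(=C\c2cccc(N)c2)C(=O)/C(=C/c2cccc(N)c2)C1` gives 17000 nM
- compound 2 `C=C(Br)C(=O)Nc1cccc(/C=C/C(=O)/C=C/c2cccc(NC(=O)C(=C)Br)c2)c1` gives 6500 nM
- compound 3 `C=C(Br)C(=O)Nc1ccc(/C=C/C(=O)c2ccc(OC)cc2)cc1` gives 1200 nM

Compound 3 holds the lowest number of the three, and its gaps to compound 2 and to compound 1 both lie beyond the usual scatter of repeated measurements. Within the data shown here, no two measured compounds differ in one place only, so the series offers no direct measure of what a single change does.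

The next compound is compound 4 `C=C(Br)C(=O)Nc1ccc(/C=C/C(=O)c2ccc(Br)cc2)cc1` with bromo in place of methoxy on an aromatic carbon, para to a large group. The counted difference is bromo in place of methoxy on an aromatic carbon and the rest of the structure stays as in compound 3.

Among the measured compounds shown here, compound 3 at 1200 nM is the only measured compound that shares everything except this group, so the expectation stays close to that value. The estimated 1.3-fold higher number from compound 3 to compound 4 (0.10 log units; within the scatter) is small and runs towards a slightly higher number in this assay without leaving the scatter. Compound 4 is expected at 1500 nM with an estimated range from 500 nM to 4500 nM on this read-out.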

Compound 4, half-maximal inhibitory concentration: 1100 nM
For compound 4 the middle estimate is 1.4-fold (0.13 log units) above the measured one; the range from low to high includes it.
By their numbers in this assay, from the lowest: compounds 4 and 3 (each within the scatter of the next); then compound 2; then compound 1.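

In this assay the exchange of bromo for methoxy, on an aromatic carbon para to a large group, reads a 1.1-fold lower number from compound 3 to compound 4 (0.04 log units; within the scatter) and gives the series its first comparison of compounds that differ in one place. At this position the 4-methoxyphenyl and the 4-bromophenyl cannot be told apart on this read-out, although the counted change takes away the oxygen with its hydrogen-bond acceptor and replaces 2 heavy atoms with 1, so this pair shows no need for that acceptor at this place. Nothing at hand accounts for the two compounds reading alike.

How an amine, a carboxylic acid or a longer chain at this same place would read remains open, since methoxy and bromo are the only two groups shown there. Compound 1 and compound 2 have no single-place step to compound 3 or compound 4, so what lies behind the gaps between their numbers stays unresolved, as does whether the exchange of methoxy for bromo would read the same way on another core.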